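Aryl replacement on the alkene carbon of compound 2

This account rests on a few compounds, and the source may have more. Where it says the series, first, only, none or still open, it means among the compounds named here.

The series is followed in a functional assay on DU-145 cells (Homo sapiens) for inhibition, read by trypan blue exclusion, with a stated time of 96 h; a lower number here means a stronger inhibitor of growth, a higher number a weaker inhibitor of growth. Compound 2 `Cc1ccc(CS/C(=C/c2cc([N+](=O)[O-])ccc2F)C(=O)c2ccc(Cl)cc2)cc1` gives 1000 nM in this assay. Compound 1 `COc1cc(OC)c(/C=C(/SCc2ccc(Cl)cc2)C(=O)c2ccc(Br)cc2)c(OC)c1` gives 1000 nM, level with compound 2 at the digits recorded and within the scatter, so no order between the two can be stated; together they hold the lowest numbers of the three measured. Compound 3 `Cc1ccc(S/C(=C/c2cc([N+](=O)[O-])ccc2F)C(=O)c2ccc(Cl)cc2)cc1` gives 10000 nM, the highest number measured; the step of a 10-fold higher number from compound 2 to compound 3 (1.00 log units; beyond the scatter) is beyond the scatter and concerns the group on the sulfur only.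

Compound 4 `Cc1ccc(CS/C(=C/c2cc(C)ccc2C)C(=O)c2ccc(Cl)cc2)cc1` has not been measured. It differs from compound 2 in one place: 2,5-dimethylphenyl in place of 2-fluoro-5-nitrophenyl on a double-bonded chain carbon bound to a double-bonded chain carbon. Within the data shown here, no measured step changes this aryl group, so none bears directly on the expected size. Compound 1 and compound 2 carry different aryl groups on the same chain carbon, beside other differences, and still give the same number, which gives no sign that this position controls the read-out. The expected step of no change at the digits printed from compound 2 to compound 4 (within the scatter) is therefore none beyond the scatter. Compound 4 is estimated at 1000 nM, with a range from 300 nM to 5000 nM.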

Compound 4, concentration for 50% growth inhibition: 10000 nM
Beside the measured number, compound 4's estimate is 10-fold (1.00 log units) below it, and the stated range ends below it.
By their numbers in this assay, from the lowest: compounds 1 and 2 (each within the scatter of the next); then compounds 3 and 4 (each within the scatter of the next).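

In this assay, 2,5-dimethylphenyl in place of 2-fluoro-5-nitrophenyl on a double-bonded chain carbon bound to a double-bonded chain carbon gives a 10-fold higher number from compound 2 to compound 4 (1.00 log units; beyond the scatter). Among these compounds, this is the first direct reading at this position, and it shows that the aryl group here does affect the number, so the series now has a step beyond the scatter at this position as well as the one on the sulfur. The entering group is carbon only, with 0 hydrogen-bond acceptors against 2 in the group that leaves, but no measurement shown ties the step to that count or to any other property of the two groups.

The change replaces the fluorine, the nitro group and both of their places on the ring in a single step, so the compounds shown do not tell whether one of the two groups alone accounts for the difference from compound 2. Also open, going by these compounds, is how this aryl group would read with a nitrile, an amine or a carboxylic acid in place of the nitro group, with the rest of compound 2 held constant.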